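This account rests on a few compounds, and the source may have more. Where it says the series, first, only, none or still open, it means among the compounds named here.

Working notes on the series. Compound 3 `CN(C)C12CC(OC(=O)C(C)(C)C)C(C(c3ccccc3)C1)C(c1ccccc1)C2` stands lowest of the two numbers in an ADME assay on L6 cells (Rattus norvegicus) for cytotoxicity, with a stated time of 72 h; a higher number here means a weaker inhibitor, a lower number a stronger inhibitor; compound 3 gives 5060 nM. Among the measured compounds shown here, compound 1 `CC(C)(C)C(=O)OC1CC2(N3CCCCC3)CC(c3ccccc3)C1C(c1ccccc1)C2` is its nearest neighbour, and in this assay compound 1 gives 12000 nM; the step of a 2.4-fold lower number from compound 1 to compound 3 (0.38 log units; beyond the scatter) is the only measured step in the set. Compound 2 `CC(=O)OC1CC2(N3CCCCC3)CC(c3ccccc3)C1C(c1ccccc1)C2` has "not determined" (no result reported) in this assay. Compound 4 `CN(C)C12CC(OC(=O)CN3CCCCC3)C(C(c3ccccc3)C1)C(c1ccccc1)C2` differs from compound 3 by (piperidin-1-yl)methyl in place of tert-butyl on a carbonyl carbon. For the measured compounds named here, no measured step touches the carbonyl carbon; the one known step, a 2.4-fold lower number from compound 1 to compound 3 (0.38 log units; beyond the scatter), concerns the saturated ring carbon and gives no guide here. The step expected for compound 4 is therefore small, a 1.0-fold lower number from compound 3 to compound 4 (0.01 log units; within the scatter), in no set direction. Compound 4 is estimated at 5000 nM in this assay, ranging from 1800 nM to 14000 nM.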

Compound 4, half-maximal inhibitory concentration: 29300 nM
Compound 4: middle estimate off by 5.9-fold (0.77 log units), on the low side; measured number above the stated range.
By their numbers in this assay, from the lowest: compound 3; then compound 1; then compound 4.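

Among the compounds shown here, the carbonyl carbon proves responsive in this assay: a 5.8-fold higher number from compound 3 to compound 4 (0.76 log units; beyond the scatter) marks the first measured change at this position. Replacing tert-butyl with (piperidin-1-yl)methyl there moves the number upward, towards weaker inhibition, so this position is not neutral for the dimethylamino compounds. No measurement at hand accounts for the step.

As far as these compounds go, it remains open whether an amine such as morpholin-4-ylmethyl or a carboxylic acid at this carbonyl carbon would move the number the same way. The compounds shown also cannot say whether the step depends on the (piperidin-1-yl)methyl ring or on its nitrogen.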